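The source may hold more compounds than are shown below. What is called first, only, known or untested is meant among the compounds shown, and "the series" means these compounds.

Measured compounds:
compound 1 `CSc1nn(-c2ccccc2)c2ncnc(N/N=C/c3ccc(N)cc3)c12` gives 12 nM
compound 2 `CSc1nn(-c2ccccc2)c2ncnc(N/N=C/c3ccc(F)cc3)c12` gives 7.5 nM
compound 3 `CSc1nn(-c2ccccc2)c2ncnc(N/N=C/c3ccc(O)cc3)c12` gives 10.3 nM

All three were run in a functional assay on MCF7 cells (Homo sapiens) for inhibition, read by sulforhodamine B assay, with a stated time of 48 h; on this read-out lower numbers stand for stronger inhibition and higher numbers for weaker inhibition. On these numbers compound 1 stands highest of the three, but every step from it lies within the scatter: a 1.6-fold lower number from compound 1 to compound 2 (0.20 log units; within the scatter) and a 1.2-fold lower number from compound 1 to compound 3 (0.07 log units; within the scatter). The step between the other two, a 1.4-fold higher number from compound 2 to compound 3 (0.14 log units; within the scatter), is likewise within the scatter. No ordering among the three can be read from this assay.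

Compound 4 `COc1cccc(/C=N/Nc2ncnc3c2c(SC)nn3-c2ccccc2)c1` is not yet measured. It differs from compound 1 in one place: 3-methoxyphenyl in place of 4-aminophenyl on a carbon with a double bond to nitrogen. The measured steps that bear on this change are those that alter the same aryl ring, namely the step from compound 1 to compound 2 and the step from compound 1 to compound 3. Both were within the scatter, so within this series the three substituents tried on that ring have not moved the number in this assay beyond what repeated measurement would show. The change to compound 4 is a different kind of substituent at a different position on that ring, so the prior steps do not cover it exactly, but nothing measured points to a direction.

Compound 4 is therefore expected to come out near compound 1, with a step of a 1.1-fold lower number from compound 1 to compound 4 (0.04 log units; within the scatter) in this assay, that is none beyond the scatter. The estimate for compound 4 is 11 nM, with a range from 4 nM to 30 nM.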

Compound 4, half-maximal inhibitory concentration: 11.1 nM
Beside the measured number, compound 4's estimate is 1.0-fold (0.00 log units) below it; the measured number falls inside the stated range.
By their numbers in this assay, from the lowest: compounds 2, 3, 4 and 1 (each within the scatter of the next).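

Working notes on the aryl group on the carbon with a double bond to nitrogen. In this assay, for the compounds shown here, this is the first change that alters both the substituent and its ring position, and the number stays within the scatter (a 1.1-fold lower number from compound 1 to compound 4 (0.03 log units; within the scatter)). The same holds against the other two measured aryl groups (a 1.1-fold higher number from compound 3 to compound 4 (0.03 log units; within the scatter); a 1.5-fold higher number from compound 2 to compound 4 (0.17 log units; within the scatter)), so all four compounds remain unordered in this assay. The swap to compound 4 also goes from 1 hydrogen-bond donor on 4-aminophenyl to 0 on 3-methoxyphenyl, and the heavy-atom count rises from 7 to 8, yet neither difference comes with a step beyond the scatter, so a donor on this aryl group is not required for a value in this range among the compounds shown.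

Still open, on these data alone, is whether a carboxylic acid, a dimethylamino group or a longer alkoxy chain on this aryl ring, or a saturated ring in its place, would give a step beyond the scatter. As far as these compounds go, no measurement at hand accounts for how closely these four values sit, and the shared core and its methylsulfanyl group remain untested by these steps.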